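The compounds below may be only part of what the source reports. "The series", "measured", "known", "first", "only" and "open" are said of these compounds alone.

Of the compounds shown here, three of a shared core have been measured in a functional assay on cells (Pituitary gland cell) for antagonist activity at Gonadotropin-releasing hormone receptor (Rattus norvegicus); on this read-out higher numbers stand for weaker inhibition and lower numbers for stronger inhibition. Compound 1 `Cc1cc(-c2c(O)nc3cc(Cl)c([N+](=O)[O-])cc3c2OCCC2CCCCN2)cc(C(C)O)c1` gives 63 nM in this assay. Compound 2 `O=[N+]([O-])c1cc2c(OCCC3CCCCN3)c(-c3cc(C(F)(F)F)cc(C(F)(F)F)c3)c(O)nc2cc1Cl` gives 71 nM, and compound 3 `Cc1ccc(-c2c(O)nc3cc(Cl)c(NC(=O)NC4CC4)cc3c2OCCC2CCCCN2)cc1C` gives 6 nM. Among these three numbers compound 1 stands second highest: its nearest neighbour is compound 2, whose number lies within the usual scatter of the assay, while compound 3 is furthest away, with a number well below that of compound 1 and beyond the scatter.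

The next compound, compound 4 `CC(=O)OCc1cc(C)cc(-c2c(O)nc3cc(Cl)c([N+](=O)[O-])cc3c2OCCC2CCCCN2)c1`, has not yet been measured. It differs from compound 1 in one place only: acetoxymethyl in place of 1-hydroxyethyl on an aromatic carbon. Cut one bond further out, the same difference reads 3-(1-hydroxyethyl)-5-methylphenyl to 3-(acetoxymethyl)-5-methylphenyl. Among the compounds with values here, no pair of measured compounds shows this change, so the data give no direct guide to its effect, and the step from compound 1 to compound 4 must be judged from the structures alone.

The account expects the step of a 1.3-fold higher number from compound 1 to compound 4 (0.13 log units; within the scatter) to be small, at most a modest rise in the number and possibly nothing beyond the scatter. Compound 4 is therefore estimated to give 85 nM, with a likely range from 30 nM to 250 nM.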

Compound 4, half-maximal inhibitory concentration: 45 nM
For compound 4 the middle estimate is 1.9-fold (0.28 log units) above the measured one; measured number inside the range.
By their numbers in this assay, from the lowest: compound 3; then compounds 4, 1 and 2 (each within the scatter of the next).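

In this assay, within the data shown here, the first single-place comparison in this set puts acetoxymethyl in place of 1-hydroxyethyl on an aromatic carbon, meta to a methyl group, and gives a 1.4-fold lower number from compound 1 to compound 4 (0.15 log units; within the scatter). This exchange replaces a group of 3 heavy atoms with 1 hydrogen-bond donor by a group of 5 heavy atoms with 0 hydrogen-bond donors, yet the two compounds cannot be told apart on this read-out, so this position accepts both groups without a difference beyond the scatter. Nothing measured here offers an explanation for this result.

The compounds shown leave open whether a hydroxymethyl group, an amine, a carboxylic acid or a longer chain on this aromatic carbon would also stay within the scatter of compound 1 or would move the number beyond it. They also leave open whether acetoxymethyl and 1-hydroxyethyl would remain indistinguishable on the core of compound 3, which carries a cyclopropyl urea in place of the nitro group.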